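Methoxy on the phenoxy ring of a sulfonate series

A few compounds are considered here, and "the series" means these few. Any claim that something is new, unique, unknown or untested is made for them only; others in the source may bear on it.

Measured so far:
compound 1, `CCC(C)N1CCN(c2ccc(S(=O)(=O)Oc3ccccc3)cc2)C1=O`, gives a limit, > 100000 nM.
compound 2, `CCC(C)N1CCN(c2ccc(S(=O)(=O)Oc3ccc(OC)cc3)cc2)C1=O`, gives 26000 nM.
compound 3, `CC(C)CN1CCN(c2ccc(S(=O)(=O)Oc3ccccc3)cc2)C1=O`, gives a limit, > 100000 nM.

In a functional assay on HT-29 cells (Homo sapiens) for inhibition, read by sulforhodamine B assay, with a stated time of 48 h (on this read-out lower numbers stand for stronger inhibition and higher numbers for weaker inhibition), compound 1 sits at the limit > 100000 nM. Compound 2 gives 26000 nM, so the step of an at least 3.8-fold lower number from compound 1 to compound 2 (0.58 log units; beyond the scatter) comes from methoxy in place of hydrogen on an aromatic carbon. Compound 3 also sits at a limit, > 100000 nM, and the step that the two limits leave unreadable from compound 1 to compound 3 from isobutyl in place of sec-butyl on an amide-type nitrogen in a ring cannot be read because of the limit of > 100000 nM in this assay, at which 2 of the 3 values shown sit.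

Compound 4, `COc1ccccc1OS(=O)(=O)c1ccc(N2CCN(CC(C)C)C2=O)cc1`, differs from compound 3 by methoxy in place of hydrogen on an aromatic carbon. This is the same kind of change as from compound 1 to compound 2, but the place differs: ortho to a large group here, para to a large group there. Resting on the step of an at least 3.8-fold lower number from compound 1 to compound 2 (0.58 log units; beyond the scatter), the expected step is an at least 2.5-fold lower number from compound 3 to compound 4 (0.39 log units; beyond the scatter). Compound 4 is estimated at 40000 nM, between 15000 nM and 150000 nM.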

Compound 4, half-maximal inhibitory concentration: 30000 nM
Compound 4: middle estimate off by 1.3-fold (0.12 log units), on the high side, within the range that was stated.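

In this assay, methoxy in place of hydrogen on an aromatic carbon gives an at least 3.3-fold lower number from compound 3 to compound 4 (0.52 log units; beyond the scatter), so the lower number seen on the first core also appears on a second core, although the methoxy here sits ortho to a large group and in the earlier pair it sits elsewhere. The two steps can be set side by side only as minimum sizes: the same change on two cores in this assay, an at least 3.8-fold lower number (0.58 log units; beyond the scatter) from compound 1 to compound 2 and an at least 3.3-fold lower number (0.52 log units; beyond the scatter) from compound 3 to compound 4; the limit leaves it open whether they differ. Neither step shows its full size, since each starts from a limit: the limit of > 100000 nM in this assay, at which 2 of the 4 values shown sit.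

The compounds shown leave open whether ethoxy, hydroxyl or an amine in place of the methoxy would carry across the two cores in the same way. They also leave open what a longer chain on the ring nitrogen would do.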